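The source may hold more compounds than are shown below. What is called first, only, known or untested is meant among the compounds shown, and "the series" means these compounds.

Working notes on the series, read in a functional assay on NCI-H661 cells (Homo sapiens) for inhibition, read by MTT assay, with a stated time of 72 h; on this read-out lower numbers stand for stronger inhibition and higher numbers for weaker inhibition. Compound 1 (`Nc1ccccc1NC(=O)c1ccc(CNCc2nc(-c3cccs3)no2)cc1`) gives 35800 nM. Compound 2 (`O=C(NO)c1ccc(CNCc2nc(-c3ccccc3)no2)cc1`) reads > 100000 nM, which is a limit of the assay and not a number. That places compound 2 at the limit of > 100000 nM in this assay, at which 1 of the 2 values shown sits.

Compound 3 (`O=C(NO)c1ccc(CNCc2nc(-c3ccc(F)cc3)no2)cc1`) differs from compound 2 by fluoro in place of hydrogen on an aromatic carbon, phenyl to 4-fluorophenyl. Among the compounds with values here, no measured pair sizes this change. In this assay no step beyond the usual scatter is therefore expected, and no direction is favoured. The expected change is a number no higher from compound 2 to compound 3 (the limit leaves the size open). A further reading at the limit of the assay is also quite possible. For compound 3 the estimated value is 100000 nM, with an expected range of 30000 nM to 300000 nM.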

Compound 3, half-maximal inhibitory concentration: > 100000 nM
Compound 3: only a limit was reported (the forecaster's own chance of this, stated with the estimate: 60%); the middle value sits exactly at the limit.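

Within the data shown here, compound 2 and compound 3 both stand at a limit and not at a number, so no step from phenyl to 4-fluorophenyl can be read between them. Still open, from the compounds shown here alone, is whether fluoro in place of hydrogen on that aromatic carbon shifts the read-out at all, and in which direction.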